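Chain length on the thioether linker of the shared core

This account rests on a few compounds, and the source may have more. Where it says the series, first, only, none or still open, it means among the compounds named here.

Measured so far:
compound 1 `CCOC(=O)CCCSc1nc2cc(-n3nc(C(C)(C)C)sc3=O)c(F)cc2s1` — 8670 nM
compound 2 `CCOC(=O)CCSc1nc2cc(-n3nc(C(C)(C)C)sc3=O)c(Br)cc2s1` — 27500 nM

Of the compounds shown here, two have been tested in an assay on isolated protein for inhibition of protoporphyrinogen oxidase (Homo sapiens), read by capillary electrophoresis; on this read-out lower numbers stand for stronger inhibition and higher numbers for weaker inhibition. Compound 1 `CCOC(=O)CCCSc1nc2cc(-n3nc(C(C)(C)C)sc3=O)c(F)cc2s1` gives 8670 nM in this assay. Compound 2 `CCOC(=O)CCSc1nc2cc(-n3nc(C(C)(C)C)sc3=O)c(Br)cc2s1` gives 27500 nM and stands at the highest number of the two, with compound 1 at a lower number; the gap between the two lies beyond the scatter. The two differ in two places at once, the halogen on the shared core and the length of the chain on sulfur, so the gap cannot be attributed to either change on its own.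

Compound 3 `CCOC(=O)CCCSc1nc2cc(-n3nc(C(C)(C)C)sc3=O)c(Br)cc2s1` has not yet been measured. The change from compound 2 is (ethoxycarbonyl)methyl in place of ethoxycarbonyl on a saturated chain carbon, two bonds along the chain from a sulfur. For the measured compounds named here, no single-change step with this chain lengthening is available. Compound 1 carries the longer chain and gives the lower number, but its halogen also differs, so the direction remains uncertain. The expected step for compound 3 is a 1.8-fold lower number from compound 2 to compound 3 (0.26 log units; within the scatter), a modest move toward a lower number or none beyond the scatter. For compound 3 the estimate in this assay is 15000 nM, with a range from 5000 nM to 45000 nM.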

Compound 3, inhibition constant: 245000 nM
The estimate for compound 3 lay 16-fold (1.21 log units) below the measured number; measured number above the stated range.
By their numbers in this assay, from the lowest: compound 1; then compound 2; then compound 3.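

With the halogen held at bromo, the chain on sulfur can now be read alone in this assay: 3-(ethoxycarbonyl)propyl in place of 2-(ethoxycarbonyl)ethyl gives an 8.9-fold higher number from compound 2 to compound 3 (0.95 log units; beyond the scatter) and so raises the number, the opposite of what compound 1 had hinted at. With the chain held at 3-(ethoxycarbonyl)propyl, the halogen can also be read alone: bromo in place of fluoro on an aromatic carbon gives a 28-fold higher number from compound 1 to compound 3 (1.45 log units; beyond the scatter) and is the larger of the two steps. If the two steps add, the gap between compound 1 and compound 2 is what remains when they partly cancel, so that gap understated how much each change matters.

Still open, from the compounds shown here alone, is whether the chain step holds with fluoro on the shared core, and whether the halogen step holds on the 2-(ethoxycarbonyl)ethyl chain. Also open, going by these compounds, is how a longer chain, or a carboxylic acid in place of the ethyl ester, would read on this core.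

Nothing measured here accounts for the size of either step.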